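A few compounds are considered here, and "the series" means these few. Any claim that something is new, unique, unknown or untested is made for them only; others in the source may bear on it.

Compound 1, `COc1cc(C(=O)c2sc(-c3ccc(Br)cc3)cc2N)cc(OC)c1OC`, was tested in a functional assay on CCRF-CEM cells (Homo sapiens) for antiproliferative activity (a lower number here means a stronger inhibitor, a higher number a weaker inhibitor), and gave 86 nM. Its companion compound 2, `COc1cc(C(=O)c2sc(-c3ccncc3)cc2N)cc(OC)c1OC`, carries a pyridin-4-yl in place of the 4-bromophenyl on an aromatic carbon and gave 110 nM. Of the two numbers, that of compound 1 is the smaller, yet a 1.3-fold higher number from compound 1 to compound 2 (0.11 log units; within the scatter) means the two compounds cannot be told apart on this evidence.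

Compound 3, `COc1cc(C(=O)c2sc(-c3ccc(C(F)(F)F)cc3)cc2N)cc(OC)c1OC`, keeps the shared core and differs from compound 1 only in one spot: trifluoromethyl in place of bromo on an aromatic carbon. Within the data shown here, no measured step swaps a bromo for a trifluoromethyl, so the only step that offers any guidance is the one from compound 1 to compound 2, where replacing the whole 4-bromophenyl by a pyridin-4-yl left the number within the scatter. A smaller change at the same aromatic carbon is therefore expected to move the number little, in no particular direction, and a 1.2-fold higher number from compound 1 to compound 3 (0.07 log units; within the scatter) is the step estimated here. On that basis compound 3 is expected to give about 100 nM in this assay, with a likely range from 40 nM to 250 nM.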

Compound 3, half-maximal inhibitory concentration: 270 nM
For compound 3 the middle estimate is 2.7-fold (0.43 log units) below the measured one, outside the stated range (above it).
By their numbers in this assay, from the lowest: compounds 1 and 2 (each within the scatter of the next); then compound 3.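

Among these compounds, this result shows that the group on the phenyl ring is not a free choice, as the single earlier step might have suggested. Exchanging bromo for trifluoromethyl gives a 3.1-fold higher number from compound 1 to compound 3 (0.50 log units; beyond the scatter) in this assay and so weakens the compound measurably, if modestly, while the earlier replacement of the entire 4-bromophenyl by pyridin-4-yl stayed within the scatter. Compound 3 also stands apart from the pyridine-bearing compound, with a 2.5-fold higher number from compound 2 to compound 3 (0.39 log units; beyond the scatter), so a single group at this place can separate compounds whose aromatic rings differ, and no data here offer a reason for that loss of activity.

With only bromo and trifluoromethyl compared on the phenyl ring, two examples cannot show which feature of the group sets the number, or whether bromo is close to the best choice. A chlorine, a methoxy group or an amine at the same place on the shared core would show whether compound 3 is an isolated case or part of a wider trend.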